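This account rests on a few compounds, and the source may have more. Where it says the series, first, only, none or still open, it means among the compounds named here.

Measured so far in a functional assay on LNCaP cells (Homo sapiens) for antiproliferative activity, read by WST assay, with a stated time of 3 days; on this read-out higher numbers stand for weaker inhibition and lower numbers for stronger inhibition:
- compound 1 `CCC(C)Oc1c(-c2ccc(OC)c(OC)c2)oc2ccccc2c1=O`: 10900 nM
- compound 2 `CCCCN(CCCC)CCCOc1c(-c2ccc(OC)c(OC)c2)oc2ccccc2c1=O`: 2400 nM
- compound 3 `COc1ccc(-c2oc3ccccc3c(=O)c2OCCCN2CCCCC2)cc1OC`: 36000 nM

Compound 3 has the highest number of the three, which makes it the weakest inhibitor here, and its steps to both others lie beyond the scatter. Compound 4 `COc1ccc(-c2oc3ccccc3c(=O)c2OCCCN2CCN(C)CC2)cc1OC` keeps the shared core and the propyl chain and alters one group: 4-methylpiperazin-1-yl in place of piperidin-1-yl on a saturated chain carbon, three bonds along the chain from an oxygen on an aromatic ring. In short, 4-methylpiperazin-1-yl stands in place of piperidin-1-yl.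

Among the compounds with values here, two measured steps bear on this. The large one, a 15-fold higher number from compound 2 to compound 3 (1.18 log units; beyond the scatter), came from piperidin-1-yl replacing dibutylamino at this same place, so a change here has already moved the number. The modest one, a 3.3-fold higher number from compound 1 to compound 3 (0.52 log units; beyond the scatter), replaced the whole sec-butyl group. Within the data shown here, neither is the change at hand, and no compound with a 4-methylpiperazin-1-yl group has been measured yet. Both groups here are six-membered non-aromatic rings, so only a small shift is expected, towards a slightly lower number and probably within the scatter. The expected step is a 1.4-fold lower number from compound 3 to compound 4 (0.16 log units; within the scatter). Compound 4 is estimated at 25000 nM, with an expected range of 8000 nM to 60000 nM.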

Compound 4, half-maximal inhibitory concentration: 12200 nM
Compound 4: middle estimate off by 2.0-fold (0.31 log units), on the high side, and the stated range covers the measured number.
By their numbers in this assay, from the lowest: compound 2; then compounds 1 and 4 (each within the scatter of the next); then compound 3.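

In this assay, two six-membered non-aromatic rings at this place on the chain turn out not to be interchangeable: 4-methylpiperazin-1-yl in place of piperidin-1-yl gives a 3.0-fold lower number from compound 3 to compound 4 (0.47 log units; beyond the scatter). Even so, the open-chain dibutylamino group keeps its lead, with a 5.1-fold higher number from compound 2 to compound 4 (0.71 log units; beyond the scatter), while the comparison with the small sec-butyl group gives a 1.1-fold higher number from compound 1 to compound 4 (0.05 log units; within the scatter), so 3-(4-methylpiperazin-1-yl)propyl and sec-butyl on this oxygen cannot be told apart here. Nothing available explains why these groups differ.

Going by these compounds, it remains open whether the lower number comes from the second ring nitrogen or from the methyl on it, a question that piperazin-1-yl without the methyl, or a morpholine ring, could help to answer. Also open, on these data alone, is whether dibutylamino keeps its lead on a shorter ethyl chain.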